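The source may hold more compounds than are shown below. What is called first, only, known or untested is meant among the compounds shown, and "the series" means these compounds.

Among the measured compounds shown here, in a functional assay on MV4-11 cells (Homo sapiens) for inhibition, read by resazurin assay, with a stated time of 72 h (a lower number here means a stronger inhibitor of growth, a higher number a weaker inhibitor of growth), compound 1 (`COCCSc1nc(C)c(-c2ccnc(Nc3ccc(OC)cc3OC)n2)s1`) gives 810 nM, the lowest of the three numbers measured so far. Compound 2 (`COc1ccc(Nc2nccc(-c3cn(C(C)C)c4ccccc34)n2)c(OC)c1`) gives 3250 nM and compound 3 (`CCCn1cc(-c2ccnc(Nc3ccc(OC)cc3OC)n2)c2ccccc21`) gives 3620 nM, and both values lie beyond the scatter above that of compound 1. The next compound to be tested, compound 4 (`CCCSc1nc(C)c(-c2ccnc(Nc3ccc(OC)cc3OC)n2)s1`), keeps the core of compound 1 and changes only the chain on sulfur: it has methyl in place of methoxy on a saturated chain carbon, two bonds along the chain from a sulfur, so that 2-methoxyethyl becomes propyl (methyl in place of methoxy on a saturated chain carbon, two bonds along the chain from a sulfur).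

For the measured compounds named here, only one measured step offers any guide, and it is a 1.1-fold higher number from compound 2 to compound 3 (0.05 log units; within the scatter), with propyl in place of isopropyl on an aromatic nitrogen. That step also brings in propyl, but at a different place, and it stays within the scatter. Going by the values given here, no measured pair shows what removing the methoxy does, so the evidence for a direction is thin. No shift beyond the scatter is therefore expected, and the estimated step is a 1.1-fold lower number from compound 1 to compound 4 (0.03 log units; within the scatter). For compound 4 the estimated value is 750 nM, with an expected range from 300 nM to 1900 nM.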

Compound 4, concentration for 50% growth inhibition: 2240 nM
For compound 4 the middle estimate is 3.0-fold (0.48 log units) below the measured one; measured number outside the range, above it.
By their numbers in this assay, from the lowest: compound 1; then compounds 4, 2 and 3 (each within the scatter of the next).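

In this assay the change from 2-methoxyethyl to propyl on sulfur gives a 2.8-fold higher number from compound 1 to compound 4 (0.44 log units; beyond the scatter) and so lies beyond the scatter, though the step is modest. This makes the chain on sulfur the only place among the compounds shown where a single change moves the number that far, whereas the one earlier step, a 1.1-fold higher number from compound 2 to compound 3 (0.05 log units; within the scatter) for propyl in place of isopropyl on an aromatic nitrogen, stayed within the scatter and said nothing about this chain. Here the lower number goes with the methoxy-bearing chain and the higher number with propyl, but no measurement at hand accounts for that difference.

The compounds shown leave open whether the oxygen itself or the whole 2-methoxyethyl chain goes with the lower number, since a single pair cannot separate the two. Also open, as far as these compounds go, is how a hydroxyl or an amine at the same chain carbon, or a longer ether chain on sulfur, would compare with compound 1 in this assay and whether any of them would give a still lower number.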